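This account rests on a few compounds, and the source may have more. Where it says the series, first, only, none or still open, it means among the compounds named here.

Of the compounds shown here, three have been measured in an assay on isolated protein for inhibition of histone acetyltransferase p300 (Homo sapiens), with a stated time of 60 min (on this read-out higher numbers stand for weaker inhibition and lower numbers for stronger inhibition), and a fourth awaits its result. Compound 1 `O=C(Nc1ccc2[nH]ncc2n1)[C@H]1CCCN1C(=O)C1(c2cccc(Cl)c2)CCCC1` gives 0.159 nM in this assay. Compound 2 `COc1ccc(NC(=O)[C@H]2CCCN2C(=O)C2(c3cccc(Cl)c3)CCCC2)cc1` differs from compound 1 in a single place: a group of 8 heavy atoms (7 carbon, 1 oxygen; one six-membered aromatic ring of carbon only) in place of a group of 9 heavy atoms (6 carbon, 3 nitrogen; one five-membered aromatic ring with 2 hetero atoms, one six-membered aromatic ring with 1 hetero atom), on an amide-type nitrogen. In this assay compound 2 gives 100 nM. This exchange produced a 630-fold higher number from compound 1 to compound 2 (2.80 log units; beyond the scatter), so the bicyclic group on the amide nitrogen appears to matter a great deal for inhibition in this pair.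

Compound 3 `O=C(Nc1ccc2[nH]ncc2n1)[C@H]1CCCN1C(=O)C1(c2ccc(Cl)cc2)CCC1` carries the same bicyclic group as compound 1 but on a different core; the difference between the two cores is not broken down here. In this assay compound 3 gives 0.1 nM, a number that sits within the usual scatter of the value for compound 1, so the two cannot be told apart on this read-out.

Compound 4 `COc1ccc(NC(=O)[C@H]2CCCN2C(=O)C2(c3ccc(Cl)cc3)CCC2)cc1` is to compound 3 what compound 2 is to compound 1: a group of 8 heavy atoms (7 carbon, 1 oxygen; one six-membered aromatic ring of carbon only) in place of a group of 9 heavy atoms (6 carbon, 3 nitrogen; one five-membered aromatic ring with 2 hetero atoms, one six-membered aromatic ring with 1 hetero atom), on an amide-type nitrogen. The surroundings of the exchange are the same in both pairs, so this is the same change made on a second core.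

Among the compounds with values here, since the only earlier example of this change is the step of a 630-fold higher number from compound 1 to compound 2 (2.80 log units; beyond the scatter), and since compound 3 starts from 0.1 nM, the step from compound 3 to compound 4 is expected to be about a 600-fold higher number from compound 3 to compound 4 (2.78 log units; beyond the scatter) in this assay. On that basis compound 4 is estimated to give 60 nM, most likely somewhere between 15 nM and 250 nM, resting on a single precedent and therefore open to a wide margin.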

Compound 4, half-maximal inhibitory concentration: 10 nM
Estimate against measurement, compound 4: 6.0-fold (0.78 log units) above, outside the stated range (below it).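

In this assay, putting 4-methoxyphenyl in place of the bicyclic group on the amide-type nitrogen again weakens inhibition by a wide margin on the second core: a 100-fold higher number from compound 3 to compound 4 (2.00 log units; beyond the scatter). Within the data shown here, the direction of the change therefore carries over from one core to the other, but its size does not, and the core appears to influence how much is lost: the same change on two cores in this assay, a 630-fold higher number (2.80 log units; beyond the scatter) from compound 1 to compound 2 and a 100-fold higher number (2.00 log units; beyond the scatter) from compound 3 to compound 4, 6.3-fold (0.80 log units) apart, beyond the scatter of two such steps With only two pairs, these results show that the loss is large on both cores, but they do not show which feature of the cores sets the gap between the two steps or how large the step would be on a third core.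

The compounds shown have only these two groups on the amide-type nitrogen, so it remains open which part of the bicyclic group matters most, and whether its ring nitrogens or the amide-type hydrogen it carries are needed for such strong inhibition. It is also unknown whether an amine or a carboxylic acid in place of the methoxy group of 4-methoxyphenyl would recover any of the lost inhibition on either core.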